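Trimming the Phenyl-Tipped Chain of Compound 1

The source may hold more compounds than are shown below. What is called first, only, known or untested is meant among the compounds shown, and "the series" means these compounds.

In a functional assay on PC-3 cells (Homo sapiens) for cytotoxicity, read by sulforhodamine B assay, with a stated time of 5 days (a higher number here means a weaker inhibitor, a lower number a stronger inhibitor), compound 1 `O=C(CCCCCCCCCCCc1ccccc1)CC(=O)N[C@H]1CCOC1=O` gives 4000 nM, the lower of the two actual numbers, while compound 3 `O=C(CCCCCCCCc1ccccc1)N[C@H]1CCOC1=O` gives 67000 nM, a higher number beyond the scatter. Compound 2 `O=C(CCCCCCCCCCCc1ccccc1)N[C@H]1CCOC1=O` reads > 100000 nM, which is a limit of the assay. Compound 4 `O=C(CCCCCCCCCc1ccccc1)CC(=O)N[C@H]1CCOC1=O`, still unmeasured, keeps the core of compound 1 but has phenyl in place of phenethyl on a saturated chain carbon, nine bonds along the chain from a carbonyl carbon. Among the compounds with values here, no measured step covers this change, so no shift beyond the scatter is expected in this assay. The point of comparison is compound 1, which gives 4000 nM. The expected move is a 1.5-fold higher number from compound 1 to compound 4 (0.18 log units; within the scatter). Compound 4 is estimated at 6000 nM, with an expected range of 2000 nM to 25000 nM.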

Compound 4, half-maximal inhibitory concentration: 4000 nM
Beside the measured number, compound 4's estimate is 1.5-fold (0.18 log units) above it; low and high end bracket the measured number.
By their numbers in this assay, from the lowest: compounds 1 and 4 (each within the scatter of the next); then compound 3. At a limit, above all of these: compound 2.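

In this assay, within the data shown here, phenyl in place of phenethyl, on a saturated chain carbon, nine bonds along the chain from a carbonyl carbon, gives no change at the digits printed from compound 1 to compound 4 (within the scatter) and so shows that the read-out holds when this chain end changes, which no earlier compound covered. Nothing in the data shown bears on the reason for this flat step. Still open, on these data alone, is whether a much shorter chain, or an amine or a carboxylic acid in place of phenyl, would hold the read-out in this assay as well.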